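Hydrazone aryl variation: expectation for compound 4

The source may report more compounds than this note shows. Statements on the series, on what has been measured and on what is new or still open speak of the compounds shown alone.

Measured so far:
compound 1 `O=C(CSc1nnc(-c2ccncc2)o1)N/N=C/c1ccc(F)cc1`: 12300 nM
compound 2 `O=C(CSc1nnc(-c2ccncc2)o1)N/N=C/c1ccc(O)cc1`: 5510 nM
compound 3 `Cc1ccc(/C=N/NC(=O)CSc2nnc(-c3ccncc3)o2)cc1`: 10000 nM

In a functional assay on HepG2 cells (Homo sapiens) for cytotoxicity, read by MTT assay, with a stated time of 48 h (a higher number here means a weaker inhibitor, a lower number a stronger inhibitor), compound 1 stands at the highest of the three numbers; compound 3 is nearest, compound 2 furthest. The change hydroxy in place of fluoro gave a 2.2-fold lower number from compound 1 to compound 2 (0.35 log units; beyond the scatter), whereas methyl in place of fluoro gave a 1.2-fold lower number from compound 1 to compound 3 (0.09 log units; within the scatter).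

Compound 4 `COc1cccc(/C=N/NC(=O)CSc2nnc(-c3ccncc3)o2)c1` differs from compound 1 by 3-methoxyphenyl in place of 4-fluorophenyl on a carbon with a double bond to nitrogen. Within the data shown here, neither measured step involves 3-methoxyphenyl, so no step bears on it directly; the two steps that replace the fluoro give one modest move and one within the scatter. The step of a 1.2-fold lower number from compound 1 to compound 4 (0.09 log units; within the scatter) is therefore expected to stay within the scatter. For compound 4 the estimate in this assay is 10000 nM, with a range from 4000 nM to 25000 nM.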

Compound 4, half-maximal inhibitory concentration: 9170 nM
For compound 4 the middle estimate is 1.1-fold (0.04 log units) above the measured one; the range from low to high includes it.
By their numbers in this assay, from the lowest: compounds 2, 4, 3 and 1 (each within the scatter of the next, the first and the last beyond it).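

In this assay, the steps of a 1.3-fold lower number from compound 1 to compound 4 (0.13 log units; within the scatter) and a 1.1-fold lower number from compound 3 to compound 4 (0.04 log units; within the scatter) and a 1.7-fold higher number from compound 2 to compound 4 (0.22 log units; within the scatter) all lie within the scatter, so 3-methoxyphenyl in place of each 4-substituted phenyl group leaves the number unresolved from the earlier values. Compound 4 stands within the scatter of both compound 1 and compound 2, although those two lie beyond the scatter of each other. Nothing available explains this result.

From the compounds shown here alone, whether an amine or a carboxylic acid on this phenyl ring would move the number beyond the scatter remains open. So does how 4-methoxyphenyl would compare with 3-methoxyphenyl.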